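The compounds below may be only part of what the source reports. "The series", "measured", "known", "first", "only" and "open" are said of these compounds alone.

Compound 3 `COc1ccccc1NC(=O)Oc1cc(=O)n(CCCO)c2c1CC(C/C=C(\C)CCC=C(C)C)C(C)(C)C2` has the lowest of three numbers in a functional assay on PANC-1 cells (Homo sapiens) for inhibition, read by MTT assay, with a stated time of 24 h, tested at 10 uM (a higher number here means more inhibition at the concentration tested (going by the name of the read-out), a lower number less inhibition), where compound 3 gives 0%, though this gap to compound 1 is within the scatter. Compound 1 `CCOc1cc(=O)n(CCCO)c2c1CC(C/C=C(\C)CCC=C(C)C)C(C)(C)C2` gives 0.8%, and compound 2 `CC(C)=CCC/C(C)=C/CC1Cc2c(OCCCNC(=O)c3cccs3)cc(=O)n(CCCO)c2CC1(C)C` gives 11.5%. The step of a number 0.8 percentage points lower from compound 1 to compound 3 (within the scatter) lies within the scatter, while a number 10.7 percentage points higher from compound 1 to compound 2 (beyond the scatter) and a number 11.5 percentage points lower from compound 2 to compound 3 (beyond the scatter) are modest. Compound 4 `CC(C)=CCC/C(C)=C/CC1Cc2c(OC(=O)Nc3ccc(F)cc3F)cc(=O)n(CCCO)c2CC1(C)C` differs from compound 3 in one place: 2,4-difluorophenyl in place of 2-methoxyphenyl on an amide-type nitrogen. Among the measured compounds shown here, no measured step changes the group on the amide-type nitrogen, so none bears directly on this change; the steps into compound 3 show only that this carbamate gives a low number. A step of about a number 2 percentage points higher from compound 3 to compound 4 (within the scatter) is therefore expected, not beyond the scatter. Compound 4 is estimated at 2%, between 0% and 12%.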

Compound 4, a percentage reported as inhibition, at one concentration (the size of the read-out at that concentration, not a potency): 15.6%
Compound 4: middle estimate off by 13.6 percentage points, on the low side, and the stated range ends below it.
By their numbers in this assay, from the lowest: compounds 3 and 1 (each within the scatter of the next); then compounds 2 and 4 (each within the scatter of the next).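

Among the compounds shown here, putting 2,4-difluorophenyl in place of 2-methoxyphenyl on the amide-type nitrogen gives a number 15.6 percentage points higher from compound 3 to compound 4 (beyond the scatter) in this assay, so this group, which no earlier step changed, does move the read-out. A carbamate at this oxygen therefore need not give a low number: a number 14.8 percentage points higher from compound 1 to compound 4 (beyond the scatter), and against the 3-(((thiophen-2-yl)carbonyl)amino)propyl group the result is a number 4.1 percentage points higher from compound 2 to compound 4 (within the scatter). Nothing available explains this step. From the compounds shown here alone, whether 2-fluorophenyl or 4-fluorophenyl alone would match 2,4-difluorophenyl stays open. So does what a pyridyl or 4-carboxyphenyl group would give on this nitrogen.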